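Predicting clearance for a dimethylphenyl sulfone analogue

A few compounds are considered here, and "the series" means these few. Any claim that something is new, unique, unknown or untested is made for them only; others in the source may bear on it.

Compound 1 `COc1ccc(-c2c(S(=O)(=O)c3ccc(F)cc3)cnc3cc(F)ccc23)cc1` gives 1.77 mL/min in an ADME assay on microsomes from liver (Homo sapiens) for metabolic stability, tested at 2.5 uM; on this read-out higher numbers stand for fast clearance and lower numbers for slow clearance.
Compound 2 `COc1ccc(-c2c(S(=O)(=O)c3ccc(C)c(C)c3)cnc3cc(F)ccc23)cc1` gives 4.13 mL/min in this assay.
Compound 3 `O=S(=O)(c1ccc(F)cc1)c1cnc2cc(F)ccc2c1-c1ccc(Cl)cc1` gives 1.23 mL/min in this assay.

These three compounds share a core and differ at two places. Compound 1 and compound 3 differ at one aromatic carbon, (chloro in place of methoxy on an aromatic carbon), and in this assay this gives a 1.4-fold lower number from compound 1 to compound 3 (0.16 log units; within the scatter), so the two values cannot be told apart. Compound 1 and compound 2 differ at the sulfonyl sulfur, (3,4-dimethylphenyl in place of 4-fluorophenyl on a sulfonyl sulfur), and this change gives a 2.3-fold higher number from compound 1 to compound 2 (0.37 log units; beyond the scatter).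

Compound 4 `Cc1ccc(S(=O)(=O)c2cnc3cc(F)ccc3c2-c2ccc(Cl)cc2)cc1C` has not yet been measured in this assay. It differs from compound 3 by 3,4-dimethylphenyl in place of 4-fluorophenyl on a sulfonyl sulfur. This is the same change as that from compound 1 to compound 2, made at the same place, with the same neighbours around the sulfonyl sulfur, and only the group on the aromatic carbon of the other ring differs between the two pairs. The values of compound 1 and compound 3 sit close together. The step made here is therefore expected to resemble a 2.3-fold higher number from compound 1 to compound 2 (0.37 log units; beyond the scatter), and so an estimated 2.3-fold higher number from compound 3 to compound 4 (0.36 log units; beyond the scatter) is used. On that basis compound 4 is expected to give about 2.8 mL/min in this assay, with an expected range from 1.6 mL/min to 5 mL/min.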

Compound 4, intrinsic clearance in a liver preparation (reported as CLH), per the amount of preparation that the assay uses: 7.88 mL/min
Compound 4: the middle estimate sits 2.8-fold (0.45 log units) below what was measured; the measured number lies above the stated range.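

In this assay, 3,4-dimethylphenyl in place of 4-fluorophenyl on the sulfonyl sulfur gives a higher number on both cores, but the step with chloro on the aromatic carbon, a 6.4-fold higher number from compound 3 to compound 4 (0.81 log units; beyond the scatter), does not match the one with methoxy there: the same change on two cores in this assay, a 2.3-fold higher number (0.37 log units; beyond the scatter) from compound 1 to compound 2 and a 6.4-fold higher number (0.81 log units; beyond the scatter) from compound 3 to compound 4, 2.7-fold (0.44 log units) apart, beyond the scatter of two such steps. Chloro in place of methoxy, read among the 3,4-dimethylphenyl sulfones, gives a 1.9-fold higher number from compound 2 to compound 4 (0.28 log units; within the scatter), so that step alone stays within the scatter, yet set beside its counterpart among the 4-fluorophenyl sulfones the two still differ: the same change on two cores in this assay, a 1.4-fold lower number (0.16 log units; within the scatter) from compound 1 to compound 3 and a 1.9-fold higher number (0.28 log units; within the scatter) from compound 2 to compound 4, 2.7-fold (0.44 log units) apart, beyond the scatter of two such steps. Thus the direction of the sulfonyl change carried from one core to the other, while its size did not, and the two changes do not simply add in these four compounds, which form a single comparison and show neither why this happens nor whether it holds for other groups.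

On these data alone, how the sulfonyl step would run with a bromo, a trifluoromethyl or an amine on the aromatic carbon remains open. So does the result of placing an unsubstituted phenyl or a pyridine ring on the sulfonyl sulfur, which would show which part of 3,4-dimethylphenyl goes with the larger step.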